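Moving the Quinoline Attachment Point in an Arginine Amide Series

A few compounds are considered here, and "the series" means these few. Any claim that something is new, unique, unknown or untested is made for them only; others in the source may bear on it.

Of the compounds shown here, three sharing one core have been tested in a functional assay on HEK293 cells for antagonist activity at melanin-concentrating hormone receptor 1 (Homo sapiens); on this read-out lower numbers stand for stronger inhibition and higher numbers for weaker inhibition. Compound 1 `COc1ccc2[nH]c(C(=O)N[C@H](CCCNC(=N)N)C(=O)NCc3ccc(C(F)(F)F)cc3)cc2c1` gives 78 nM, and compound 2 `N=C(N)NCCC[C@@H](NC(=O)c1cc2cc(F)ccc2[nH]1)C(=O)NCc1ccc(C(F)(F)F)cc1` gives 25 nM; between them lies the step of a 3.1-fold lower number from compound 1 to compound 2 (0.49 log units; beyond the scatter), a fluoro in place of a methoxy on an aromatic carbon. Compound 3 `N=C(N)NCCC[C@@H](NC(=O)c1ccnc2ccccc12)C(=O)NCc1ccc(C(F)(F)F)cc1` gives 1030 nM, the highest number of the three and therefore the weakest inhibitor here, reached through a 13-fold higher number from compound 1 to compound 3 (1.12 log units; beyond the scatter) and a 41-fold higher number from compound 2 to compound 3 (1.61 log units; beyond the scatter), both large rises when a quinolin-4-yl takes the place of an indole group on the carbonyl carbon.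

Compound 4 `N=C(N)NCCC[C@@H](NC(=O)c1ccc2ccccc2n1)C(=O)NCc1ccc(C(F)(F)F)cc1` differs from compound 3 only by quinolin-2-yl in place of quinolin-4-yl on a carbonyl carbon. Within the data shown here, no measured step changes where the quinoline is attached; the two large steps measured so far concern swapping the indole for the quinoline, not its attachment point, so they give no direction for this change. The step of a 1.5-fold lower number from compound 3 to compound 4 (0.17 log units; within the scatter) is therefore expected to be small and uncertain. Compound 4 is estimated at 700 nM, within a range from 150 nM to 3500 nM.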

Compound 4, half-maximal inhibitory concentration: 904 nM
Compound 4: middle estimate off by 1.3-fold (0.11 log units), on the low side; low and high end bracket the measured number.
By their numbers in this assay, from the lowest: compound 2; then compound 1; then compounds 4 and 3 (each within the scatter of the next).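

Moving the attachment from quinolin-4-yl to quinolin-2-yl on the carbonyl carbon gives a 1.1-fold lower number from compound 3 to compound 4 (0.06 log units; within the scatter) in this assay, so these two attachment points cannot be told apart on this read-out. The large gap to the indoles is also seen with the new isomer, as a 36-fold higher number from compound 2 to compound 4 (1.56 log units; beyond the scatter) and a 12-fold higher number from compound 1 to compound 4 (1.06 log units; beyond the scatter) show, so it belongs to both quinolines and not only to quinolin-4-yl. Nothing available explains why the two quinolines read alike or why both give higher numbers than the indoles.

Still open, as far as these compounds go, is how a 1H-indol-2-yl carrying neither fluoro nor methoxy would compare with compound 1 and compound 2. Also open, from the compounds shown here alone, is whether an amine or a nitrile on the quinoline would change its number at all.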